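Isopropyl for chloro on a uracil ether chain

The compounds below may be only part of what the source reports. "The series", "measured", "known", "first", "only" and "open" are said of these compounds alone.

Compound 1 `O=c1ccn(CCCOc2ccc(Br)cc2)c(=O)[nH]1`: > 100000 nM
Compound 2 `O=c1ccn(CCCCCOc2ccc(Cl)cc2)c(=O)[nH]1`: > 100000 nM

In an ADME assay on HEL cells (Homo sapiens) for cytotoxicity, read by microscopy (on this read-out higher numbers stand for lower toxicity in this test and lower numbers for higher toxicity in this test), compound 1 gives only a limit, > 100000 nM. In this assay compound 2 likewise gives only a limit, > 100000 nM. Compound 2 therefore stands at the limit of > 100000 nM in this assay, at which 2 of the 2 values shown sit, with no number below it. Compound 3 `CC(C)c1ccc(OCCCCCn2ccc(=O)[nH]c2=O)cc1` differs from compound 2 by isopropyl in place of chloro on an aromatic carbon. Within the data shown here, with no measured step to draw on, the step of a number no higher from compound 2 to compound 3 (the limit leaves the size open) is expected to be small, none beyond the scatter. For compound 3 the expected value is 100000 nM, within 30000 nM to 200000 nM.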

Compound 3, minimum cytotoxic concentration: 100000 nM
Compound 3: middle estimate and measured number agree at the digits printed, and the stated range covers the measured number.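

In this assay compound 3 gives 100000 nM, a real number. Compound 1 and compound 2 each gave only a limit. Isopropyl in place of chloro on this aromatic carbon gives a number no higher from compound 2 to compound 3 (the limit leaves the size open), so the true size of the change cannot be read. Most of the values still stand at a limit: the limit of > 100000 nM in this assay, at which 2 of the 3 values shown sit.

Still open, from the compounds shown here alone, is how an amine or a carboxylic acid on this aromatic carbon would read in this assay. Also open, going by these compounds, is whether a longer chain alongside isopropyl would give a lower number.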